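Adding a second trifluoromethyl to compound 2

A few compounds are considered here, and "the series" means these few. Any claim that something is new, unique, unknown or untested is made for them only; others in the source may bear on it.

In a functional assay on CWR22R cells (Homo sapiens) for antiproliferative activity, read by propidium iodide staining, with a stated time of 96 h (a higher number here means a weaker inhibitor, a lower number a stronger inhibitor), compound 1 `CC(O)(CSc1ccc(C(F)(F)F)cc1)C(=O)Nc1cccc(S(F)(F)(F)(F)F)c1` gives 26900 nM, compound 2 `CC(O)(CSc1cccc(C(F)(F)F)c1)C(=O)Nc1cccc(S(F)(F)(F)(F)F)c1` gives 12900 nM and compound 3 `CC(O)(CSc1ccccc1C(F)(F)F)C(=O)Nc1cccc(S(F)(F)(F)(F)F)c1` gives 13200 nM. Compound 2 stands level with compound 3, at a 1.0-fold higher number from compound 2 to compound 3 (0.01 log units; within the scatter), and both lie under compound 1. Compound 4 `CC(O)(CSc1cc(C(F)(F)F)cc(C(F)(F)F)c1)C(=O)Nc1cccc(S(F)(F)(F)(F)F)c1` differs from compound 2 as follows: trifluoromethyl in place of hydrogen on an aromatic carbon. Within the data shown here, the nearest measured steps only relocate the single trifluoromethyl group. These are a 2.1-fold lower number from compound 1 to compound 2 (0.32 log units; beyond the scatter) and a 2.0-fold lower number from compound 1 to compound 3 (0.31 log units; beyond the scatter), both modest. Among the measured compounds shown here, no measured compound carries a second such group, so the evidence is indirect. In this assay, a modest step is expected, tentatively toward a lower number: an estimated 1.4-fold lower number from compound 2 to compound 4 (0.16 log units; within the scatter). For compound 4 the expected value is 9000 nM, with an estimated range of 3500 nM to 22000 nM.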

Compound 4, half-maximal inhibitory concentration: 4400 nM
The estimate for compound 4 lay 2.0-fold (0.31 log units) above the measured number; the measured number falls inside the stated range.
By their numbers in this assay, from the lowest: compound 4; then compounds 2 and 3 (each within the scatter of the next); then compound 1.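

Adding trifluoromethyl in place of hydrogen, meta to the trifluoromethyl group already on the six-membered aromatic ring of compound 2, gives a 2.9-fold lower number from compound 2 to compound 4 (0.47 log units; beyond the scatter) in this assay. This step changes the number of trifluoromethyl groups rather than relocating a single one, and it shows that the ring tolerates a second such group without loss in this read-out. Nothing measured here accounts for this step.

From the compounds shown here alone, it remains open whether a nitrile, a chlorine or a methoxy group in the same place would give a similar step.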